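Bromo to trifluoromethyl on the benzyl ring of compound 1

The source may report more compounds than this note shows. Statements on the series, on what has been measured and on what is new or still open speak of the compounds shown alone.

Compound 1 `COc1ccc(Cn2c(NCCNC(=N)N)nc(=O)n(Cc3ccc(Br)cc3)c2=O)cc1` has the lowest of the three numbers seen so far in a functional assay on the whole organism (strain C57Bl/6) for inhibition, with Mus musculus as the target, with a stated time of 180 min, at 48 degrees C (a higher number here means that more compound is needed for the effect, a lower number that less compound is needed), giving 0.00036 nM. Compound 2 `COc1ccc(Cn2c(=O)nc(NCCNC(=N)N)n(Cc3ccc(F)cc3)c2=O)cc1` gives 0.036 nM and compound 3 `COc1ccc(Cn2c(=O)nc(NCCNC(=N)N)n(Cc3ccccc3)c2=O)cc1` gives 0.063 nM; the step of a 1.8-fold higher number from compound 2 to compound 3 (0.24 log units; within the scatter) shows that fluoro and hydrogen at this place are not separated. Compound 1 and compound 2, bromo against fluoro, differ by two orders, beyond the scatter. Compound 4 `COc1ccc(Cn2c(NCCNC(=N)N)nc(=O)n(Cc3ccc(C(F)(F)F)cc3)c2=O)cc1` carries the change (trifluoromethyl in place of bromo on an aromatic carbon). Within the data shown here, no measured step covers trifluoromethyl at this place; the only steps known concern bromo, fluoro and hydrogen. Compound 4 is therefore expected to sit between compound 1 and compound 2, with the step of an 8.3-fold higher number from compound 1 to compound 4 (0.92 log units; beyond the scatter) estimated as a moderate rise. Estimate for compound 4: 0.003 nM, range 0.0003 nM to 0.04 nM.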

Compound 4, half-maximal effective concentration: 0.051 nM
For compound 4 the middle estimate is 17-fold (1.23 log units) below the measured one; the measured number lies above the stated range.
By their numbers in this assay, from the lowest: compound 1; then compounds 2, 4 and 3 (each within the scatter of the next).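

In this assay, among these compounds, the step of a 140-fold higher number from compound 1 to compound 4 (2.15 log units; beyond the scatter) is the first at this position to lie beyond the scatter, whereas a 1.8-fold higher number from compound 2 to compound 3 (0.24 log units; within the scatter) stays within it. On the core of compound 1, then, bromo cannot be exchanged for trifluoromethyl without a large loss, and the very low number of compound 1 is not shared by every para substituent on this ring. Nothing available bears on why this step is so large.

Open, from the compounds shown here alone, is whether the low number belongs to bromo alone: chloro, iodo or methyl in its place on the core of compound 1 would show this. Equally open, going by these compounds, is how an amine or a carboxylic acid would behave at this carbon.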